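Series notes: swapping thiophen-2-yl for phenyl

The compounds below may be only part of what the source reports. "The series", "measured", "known", "first", "only" and "open" are said of these compounds alone.

Values in an ADME assay on NIH3T3 cells (Mus musculus) for inhibition, read by MTT assay, with a stated time of 48 h; on this read-out higher numbers stand for weaker inhibition and lower numbers for stronger inhibition:
- compound 1 `c1ccc(Sc2c(-c3cccs3)nc3ccccn23)cc1`: > 100000 nM, a limit of the assay
- compound 2 `Clc1ccc(Sc2c(-c3cccs3)nc3ccccn23)cc1`: 86100 nM

For the measured compounds named here, compound 2 gives the only actual number, 86100 nM. The other result is compound 1 at the limit of > 100000 nM in this assay, at which 1 of the 2 values shown sits.

Compound 3 `Clc1ccc(Sc2c(-c3ccccc3)nc3ccccn23)cc1` has not yet been measured. It differs from compound 2 by phenyl in place of thiophen-2-yl on an aromatic carbon.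

Going by the values given here, the only measured step is an at least 1.1-fold lower number from compound 1 to compound 2 (0.06 log units; that floor lies within the scatter). That step is chloro in place of hydrogen on an aromatic carbon, so it does not cover the present exchange and gives no size or direction for it. With no measured guide, no step beyond the scatter is expected in this assay. A result reported only as a limit would also be no surprise.

The estimated change is a 1.1-fold lower number from compound 2 to compound 3 (0.03 log units; within the scatter). For compound 3 the expected value is 80000 nM, with an estimated range of 35000 nM to 150000 nM.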

Compound 3, half-maximal inhibitory concentration: 88700 nM
Estimate against measurement, compound 3: 1.1-fold (0.04 log units) below; the range from low to high includes it.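

Working notes on the position: in this assay, phenyl in place of thiophen-2-yl gives a 1.0-fold higher number from compound 2 to compound 3 (0.01 log units; within the scatter). For the compounds shown here, this is the first reading at this aromatic carbon of the five-membered aromatic ring with 2 nitrogen, and it shows that the six-membered all-carbon ring and the five-membered ring with 1 hetero atom cannot be told apart here, even though the hydrogen-bond acceptor counted in thiophen-2-yl is absent from phenyl. The exchange is read only with the chloro group in place, and compound 1 stands as a limit and not as a number: the limit of > 100000 nM in this assay, at which 1 of the 3 values shown sits.

Still open, as far as these compounds go, is whether any group at this position gives a step beyond the scatter, for example an amine or a carboxylic acid carried on the phenyl ring, or a longer alkyl chain in place of the ring. Also open, from the compounds shown here alone, is whether the phenyl and thiophen-2-yl pair reads the same way with a group other than chloro, such as methoxy, on the ring of the arylthio part.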